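1-(Methylamino)ethyl in Place of 1-Aminobutyl: Compound 4

The compounds below may be only part of what the source reports. "The series", "measured", "known", "first", "only" and "open" are said of these compounds alone.

Measured compounds:
Compound 1, `CN1CCCC[C@H]1[C@H]1COC(c2ccccc2)(c2ccccc2)O1`, gives 4400 nM.
Compound 2, `CCN1CCCC[C@H]1[C@H]1COC(c2ccccc2)(c2ccccc2)O1`, gives 6900 nM.
Compound 3, `CCC[C@H](N)[C@H]1COC(c2ccccc2)(c2ccccc2)O1`, gives 3450 nM.

All three were measured in a functional assay (brain) for displacement of a labelled ligand, with Rattus norvegicus as the target; on this read-out higher numbers stand for weaker inhibition and lower numbers for stronger inhibition. Compound 3 holds the lowest of the three numbers, but it is separated from compound 1 by a 1.3-fold lower number from compound 1 to compound 3 (0.11 log units; within the scatter) and from compound 2 by a 2.0-fold lower number from compound 2 to compound 3 (0.30 log units; within the scatter), so none of the three stands apart. The step from compound 1 to compound 2, a 1.6-fold higher number from compound 1 to compound 2 (0.20 log units; within the scatter), also stays within the scatter.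

Compound 4, `CN[C@@H](C)[C@H]1COC(c2ccccc2)(c2ccccc2)O1`, is not yet measured. It differs from compound 3 in one place: 1-(methylamino)ethyl in place of 1-aminobutyl on a saturated ring carbon. Among the measured compounds shown here, no measured step changes the same group in the same way; the nearest comparisons are the steps to compound 3 from compound 1 and compound 2, which replaced a ring-bound amine group with 1-aminobutyl and moved the number only within the scatter. On that evidence no step beyond the scatter is expected in this assay; compound 4 is estimated at 3500 nM, with a range of 1200 nM to 10000 nM, which means an expected step of a 1.0-fold higher number from compound 3 to compound 4 (0.01 log units; within the scatter).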

Compound 4, inhibition constant: 703 nM
Compound 4: middle estimate off by 5.0-fold (0.70 log units), on the high side; the whole stated range lies above it.
By their numbers in this assay, from the lowest: compound 4; then compounds 3, 1 and 2 (each within the scatter of the next).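

In this assay, among the compounds shown here, the saturated ring carbon proved sensitive to its side group for the first time: 1-(methylamino)ethyl in place of 1-aminobutyl, the entering group being the smaller by heavy atoms with the same counts of hydrogen-bond donors and acceptors, gave a 4.9-fold lower number from compound 3 to compound 4 (0.69 log units; beyond the scatter). The same group also separates compound 4 from the two compounds carrying a ring-bound amine group, with a 6.3-fold lower number from compound 1 to compound 4 (0.80 log units; beyond the scatter) and a 9.8-fold lower number from compound 2 to compound 4 (0.99 log units; beyond the scatter), whereas the earlier replacement of those groups by 1-aminobutyl had stayed within the scatter. No supporting data accompany these compounds that would account for the drop in the number at this position.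

The change shortens the chain and adds a methyl to the nitrogen in a single step, so the compounds shown cannot say which of the two carries the step. A 1-aminoethyl group or a 1-(methylamino)butyl group would separate the two, and a 1-(dimethylamino)ethyl group would show whether a second methyl on that nitrogen moves the number further.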